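A few compounds are considered here, and "the series" means these few. Any claim that something is new, unique, unknown or untested is made for them only; others in the source may bear on it.

Measured so far:
- compound 1, `CC(=O)Nc1ccc(S(=O)(=O)N2C/C(=C\c3cccnc3)C(=O)/C(=C/c3ccccc3C(F)(F)F)C2)cc1`, 9830 nM
- compound 2, `O=C1/C(=C/c2ccncc2)CN(S(=O)(=O)c2ccc(Cl)cc2)C/C1=C\c1ccccc1C(F)(F)F`, 5510 nM

Both were tested in a functional assay on SMMC-7721 cells (Homo sapiens) for cytotoxicity, read by MTT assay, with a stated time of 24 h; a higher number here means a weaker inhibitor, a lower number a stronger inhibitor. Compound 1 gives 9830 nM and compound 2 gives 5510 nM in this assay. These two numbers lie within the usual scatter of each other, so neither compound can be called the stronger or the weaker inhibitor on this evidence. Compound 1 and compound 2 also differ from each other in more than one place, so their pair says nothing about any single change.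

Compound 3, `CC(=O)Nc1ccc(S(=O)(=O)N2C/C(=C\c3ccncc3)C(=O)/C(=C/c3ccccc3C(F)(F)F)C2)cc1`, has not yet been measured in this assay. It differs from compound 2 in one place only: acetamido in place of chloro on an aromatic carbon. Among the compounds with values here, no measured pair isolates this change, so there is nothing to lean on beyond the closeness of compound 1 and compound 2. The expectation is therefore a step from compound 2 to compound 3 of a 1.4-fold higher number from compound 2 to compound 3 (0.13 log units; within the scatter), that is, no change beyond the scatter, in either direction. For compound 3 the estimate in this assay is 7500 nM, with a range from 3500 nM to 16000 nM.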

Compound 3, half-maximal inhibitory concentration: 5760 nM
The estimate for compound 3 lay 1.3-fold (0.11 log units) above the measured number, and the stated range covers the measured number.
By their numbers in this assay, from the lowest: compounds 2, 3 and 1 (each within the scatter of the next).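

In this assay, the first pair differing in one place gives a step of a 1.0-fold higher number from compound 2 to compound 3 (0.02 log units; within the scatter), with acetamido in place of chloro on an aromatic carbon para to a large group. So at this position, a group of 4 heavy atoms bringing a hydrogen-bond donor and a hydrogen-bond acceptor can stand in for a single chlorine with the numbers remaining within the scatter of each other, which compounds 1 and 2, differing in more than one place, could not show. The second one-place pair, pyridin-4-yl in place of pyridin-3-yl, gives a 1.7-fold lower number from compound 1 to compound 3 (0.23 log units; within the scatter), which is also within the scatter, so neither swap separates its two compounds, and nothing available explains why these numbers lie so close.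

What the compounds shown leave open is whether this position stays as undemanding with a free amine, a carboxylic acid or a longer chain on that aromatic carbon. On the other side of the molecule, they also leave open how a pyridin-2-yl group would compare with the pyridin-3-yl and pyridin-4-yl groups.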